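Halogen swap on the benzothiophene amide of compound 3

The compounds below may be only part of what the source reports. "The series", "measured", "known", "first", "only" and "open" are said of these compounds alone.

Compound 1 `O=C(NC1CCN(Cc2ccc(OC3CCNCC3)c(Br)c2)CC1)c1ccccn1` bears pyridin-2-yl on the carbonyl carbon and in an assay on HEK293 cells for displacement of a labelled ligand from Urotensin-2 receptor (Homo sapiens), read by fluorescence, with a stated time of 90 min (on this read-out higher numbers stand for weaker inhibition and lower numbers for stronger inhibition), compound 1 gives 120 nM. Compound 2 `O=C(NC1CCN(Cc2ccc(OC3CCNCC3)c(Br)c2)CC1)c1cc2ccccc2s1`, with 1-benzothiophen-2-yl in that place, gives 63 nM in this assay, and compound 3 `O=C(NC1CCN(Cc2ccc(OC3CCNCC3)c(Br)c2)CC1)c1cc2cc(Cl)ccc2s1`, with 5-chloro-1-benzothiophen-2-yl, gives 51 nM. The steps read a 1.9-fold lower number from compound 1 to compound 2 (0.28 log units; within the scatter), a 2.4-fold lower number from compound 1 to compound 3 (0.37 log units; beyond the scatter) and a 1.2-fold lower number from compound 2 to compound 3 (0.09 log units; within the scatter); compound 3 has the lowest number of the three, though its distance from compound 2 lies within the scatter. Compound 4 `O=C(NC1CCN(Cc2ccc(OC3CCNCC3)c(Br)c2)CC1)c1cc2cc(Br)ccc2s1` differs from compound 3 by bromo in place of chloro on an aromatic carbon. Among the measured compounds shown here, the one measured step at this carbon, a 1.2-fold lower number from compound 2 to compound 3 (0.09 log units; within the scatter), stayed within the scatter, and a halogen-for-halogen exchange is a smaller change still. No step beyond the scatter is therefore expected. For compound 4 the estimate is 45 nM (range 20 nM to 110 nM), an expected step of a 1.1-fold lower number from compound 3 to compound 4 (0.05 log units; within the scatter).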

Compound 4, half-maximal inhibitory concentration: 86 nM
Estimate against measurement, compound 4: 1.9-fold (0.28 log units) below; measured number inside the range.
By their numbers in this assay, from the lowest: compounds 3, 2, 4 and 1 (each within the scatter of the next, the first and the last beyond it).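

Bromo in place of chloro on this aromatic carbon (a 1.7-fold higher number from compound 3 to compound 4 (0.23 log units; within the scatter)) stays within the scatter, so the two halogens are not told apart here. Bromo in place of hydrogen (a 1.4-fold higher number from compound 2 to compound 4 (0.14 log units; within the scatter)) also stays within the scatter. The 5-bromo-1-benzothiophen-2-yl group does not separate from pyridin-2-yl (a 1.4-fold lower number from compound 1 to compound 4 (0.14 log units; within the scatter)), whereas the 5-chloro-1-benzothiophen-2-yl group did, by a step just beyond the scatter.

No measurement shown gives a reason for these steps. Open, as far as these compounds go, is whether a methoxy group, a nitrile or an amine on this aromatic carbon would move the number beyond the scatter.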